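Swapping the chain-end ring: furan to nitrophenyl

A few compounds are considered here, and "the series" means these few. Any claim that something is new, unique, unknown or untested is made for them only; others in the source may bear on it.

Measured in a functional assay on U-87MG ATCC cells for antiproliferative activity against U-87 MG (Homo sapiens), read by MTT assay, with a stated time of 48 h; a lower number here means a stronger inhibitor, a higher number a weaker inhibitor:
compound 1 `COc1cc(OC)c2c(=O)c(OCCCOc3ccc(/C=C/C(=O)/C=C/c4scnc4C)cc3)c(-c3cc(OC)c(OC)c(OC)c3)oc2c1` gives 40400 nM
compound 2 `COc1cc(OC)c2c(=O)c(OCCCCOc3ccc(/C=C/C(=O)/C=C/c4ccccn4)cc3)c(-c3cc(OC)c(OC)c(OC)c3)oc2c1` gives 4690 nM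
compound 3 `COc1cc(OC)c2c(=O)c(OCCCCOc3ccccc3/C=C/C(=O)/C=C/c3ccco3)c(-c3cc(OC)c(OC)c(OC)c3)oc2c1` gives 10700 nM

Compound 3 stands second highest of these three numbers. Its nearest neighbour is compound 2, whose number is lower by a margin beyond the scatter, while compound 1 sits further off with a higher number, also beyond the scatter. Compound 4 `COc1cc(OC)c2c(=O)c(OCCCCOc3ccccc3/C=C/C(=O)/C=C/c3cccc([N+](=O)[O-])c3)c(-c3cc(OC)c(OC)c(OC)c3)oc2c1` differs from compound 3 in one place: 3-nitrophenyl in place of furan-2-yl on a double-bonded chain carbon bound to a double-bonded chain carbon. Among the compounds with values here, no measured pair differs in that single place, so there is no direct precedent for this step. All three measured numbers are weak, and the step from compound 3 to compound 4 is expected to be small, a 1.3-fold lower number from compound 3 to compound 4 (0.13 log units; within the scatter), with no clear direction beyond the scatter. Compound 4 is therefore estimated at 8000 nM, within 2500 nM to 25000 nM.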

Compound 4, half-maximal inhibitory concentration: 10000 nM
Compound 4: middle estimate off by 1.3-fold (0.10 log units), on the low side; the measured number falls inside the stated range.
By their numbers in this assay, from the lowest: compound 2; then compounds 4 and 3 (each within the scatter of the next); then compound 1.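

In this assay, 3-nitrophenyl in place of furan-2-yl gives a 1.1-fold lower number from compound 3 to compound 4 (0.03 log units; within the scatter) and so leaves the two compounds indistinguishable. At this place on the chain, going from 5 to 9 heavy atoms, and from a five-membered ring with 1 hetero atom to a six-membered ring of carbon only, makes no difference that can be read in this measurement. No measured evidence offers an explanation for this result.

Still open, going by these compounds, is whether an amine or a carboxylic acid at the same place would give a number clearly apart from these.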